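A few compounds are considered here, and "the series" means these few. Any claim that something is new, unique, unknown or untested is made for them only; others in the source may bear on it.

Measured compounds:

Compound 1 `CO[C@@H]1CC=C2NN(c3ccc([N+](=O)[O-])cc3)C(=O)CC[C@]2(c2ccccc2)O1`: 7300 nM in a functional assay on SK-N-SH cells (Homo sapiens) for cytotoxicity, read by sulforhodamine B assay, with a stated time of 48 h; on this read-out higher numbers stand for weaker inhibition and lower numbers for stronger inhibition
Compound 2 `CO[C@@H]1CC=C2NN(c3ccccn3)C(=O)CC[C@]2(c2ccccc2)O1`: 2100 nM in this assay
Compound 3 `CO[C@@H]1CC=C2N(c3ccc([N+](=O)[O-])cc3)C(=O)C[C@]2(c2ccccc2)O1`: 9400 nM in this assay

Compound 1 and compound 2 share a core and differ in one place: pyridin-2-yl in place of 4-nitrophenyl on an amide-type nitrogen in a ring. This change gave a 3.5-fold lower number from compound 1 to compound 2 (0.54 log units; beyond the scatter), a step that stands clear of the usual scatter.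

Compound 3 carries a different core, a five-membered non-aromatic ring with 1 nitrogen in place of the seven-membered ring with 2 nitrogen; how the two cores differ beyond that is not broken down here. In this assay compound 3 gives 9400 nM, and compound 1 gives 7300 nM, two values that lie within the scatter of each other.

Compound 4 `CO[C@@H]1CC=C2N(c3ccccn3)C(=O)C[C@]2(c2ccccc2)O1` is not yet measured. It stands to compound 3 as compound 2 stands to compound 1: pyridin-2-yl in place of 4-nitrophenyl on an amide-type nitrogen in a ring. The surroundings are not identical, since in compound 1 the amide-type nitrogen sits next to the ring nitrogen of a seven-membered ring, three ring bonds from the fused ring atom and from the atom bearing the phenyl group, whereas in compound 3 it sits in a five-membered ring, two ring bonds from each; the change is therefore the same kind of change, not the same. For the measured compounds named here, compound 4 is expected to show a 3.4-fold lower number from compound 3 to compound 4 (0.53 log units; beyond the scatter), a step of this size because a 3.5-fold lower number from compound 1 to compound 2 (0.54 log units; beyond the scatter) is the only precedent, with added uncertainty for the different core. Compound 4 is thus expected near 2800 nM. The expected range for compound 4 runs from 1200 nM to 6500 nM.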

Compound 4, half-maximal inhibitory concentration: 5100 nM
For compound 4 the middle estimate is 1.8-fold (0.26 log units) below the measured one; the measured number falls inside the stated range.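

In this assay, pyridin-2-yl in place of 4-nitrophenyl on an amide-type nitrogen in a ring gives a 1.8-fold lower number from compound 3 to compound 4 (0.27 log units; within the scatter), so on this core the step alone cannot be told apart from repeat-measurement noise. Set beside the step on the core of compound 1, it gives no sign that the size of the change depends on the core: the same change on two cores in this assay, a 3.5-fold lower number (0.54 log units; beyond the scatter) from compound 1 to compound 2 and a 1.8-fold lower number (0.27 log units; within the scatter) from compound 3 to compound 4, 1.9-fold (0.28 log units) apart, within the scatter of two such steps The two pairs are compatible with one step of a single size on both cores, but with only one pair per core they do not establish this, nor do they show a real step on the core of compound 3 or rule out a modest difference between the cores.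

The compounds shown compare only 4-nitrophenyl and pyridin-2-yl on the amide-type nitrogen, so it remains open how an unsubstituted phenyl, a pyridin-4-yl or a 4-methoxyphenyl group would read on either core. Also open, going by these compounds, is whether an amine or a carboxylic acid on the ring atom that bears the phenyl group, in place of that phenyl group, would leave the comparison between the two cores as it stands here.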